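Working notes: methyl to butyl on the shared core

This account rests on a few compounds, and the source may have more. Where it says the series, first, only, none or still open, it means among the compounds named here.

Measured in a physicochemical assay for solubility, in phosphate buffer, with a stated time of 18 h; a higher number here means a more soluble compound, a lower number a less soluble compound:
- compound 1 `N#Cc1c(N)nc2nc(C3CC3)ncc2c1N`: 23000 nM
- compound 2 `CSc1nc(C(C)(C)C)nc2nc(N)c(C#N)c(N)c12`: 14000 nM
- compound 3 `Cc1nc(C(C)(C)C)nc2nc(N)c(C#N)c(N)c12`: 37000 nM

Compound 3 stands at 37000 nM. Compound 1 lies within the scatter of it, while compound 2 lies lower, beyond the scatter.

The next compound is compound 4 `CCCCc1nc(C(C)(C)C)nc2nc(N)c(C#N)c(N)c12`, which carries propyl in place of hydrogen on a saturated chain carbon bound to an aromatic carbon. The same difference reads as methyl to butyl.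

Among the measured compounds shown here, only one measured step bears on this change: a 2.6-fold higher number from compound 2 to compound 3 (0.42 log units; beyond the scatter). That step is modest, lies beyond the scatter and ends at the methyl compound. For the measured compounds named here, it is indirect evidence, since no measured pair extends a carbon chain. Read in reverse, it suggests that replacing methyl with a larger group gives a lower number in this assay. A drop of at least similar size is therefore expected, with wide uncertainty and no firm ceiling on its size.

The expected change is a 3.1-fold lower number from compound 3 to compound 4 (0.49 log units; beyond the scatter). For compound 4 the estimated value is 12000 nM, with an expected range of 3000 nM to 35000 nM.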

Compound 4, solubility: 6000 nM
For compound 4 the middle estimate is 2.0-fold (0.30 log units) above the measured one; the measured number falls inside the stated range.
By their numbers in this assay, from the lowest: compound 4; then compounds 2, 1 and 3 (each within the scatter of the next, the first and the last beyond it).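

Extending methyl to butyl at this place gives a 6.2-fold lower number from compound 3 to compound 4 (0.79 log units; beyond the scatter) in this assay, the first direct reading of a longer carbon chain on the shared core, and the earlier step from methylsulfanyl to methyl could only hint at this. The step of a 2.3-fold lower number from compound 2 to compound 4 (0.37 log units; beyond the scatter) also puts butyl under methylsulfanyl, so together with a 2.6-fold higher number from compound 2 to compound 3 (0.42 log units; beyond the scatter) the three groups at this place read in the order methyl, methylsulfanyl, butyl, with each step beyond the scatter and the order claimed for these three compounds only. Nothing available bears on why the number falls with butyl, and the size of the step carries no explanation with it.

With only methyl and butyl shown as simple chains, it remains open whether the number falls gradually through ethyl and propyl, drops at a single chain length, or keeps falling with a longer chain such as hexyl. On these data alone, it also remains open whether a chain of similar length ending in an amine, a hydroxyl or a carboxylic acid would stay near butyl or near methyl in this assay.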